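A few compounds are considered here, and "the series" means these few. Any claim that something is new, unique, unknown or untested is made for them only; others in the source may bear on it.

Values so far in an ADME assay on Caco-2 cells (Homo sapiens) for permeability, in the apical to basolateral direction; a higher number here means that the compound crosses the layer faster, a lower number that the compound crosses the layer more slowly:
- compound 1 (`CC(=O)N1CCN(c2cc(-c3cc(Cl)c4c(N)ncnn34)ccc2C(F)(F)F)C(=O)C1(C)C`) gives 150 nm/s as its result
- compound 2 (`CC(=O)N1CCN(c2cc(-c3cc(Cl)c4c(N)ncnn34)ccc2Cl)C(=O)C1(C)C`) gives "not determined" (no result reported) as its result
- compound 3 (`CC(=O)N1CCN(c2cc(-c3cc(Cl)c4c(N)ncnn34)ccc2S(C)(=O)=O)C(=O)C1(C)C`) gives "not determined" (no result reported) as its result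

Compound 3 has no number to stand on, and compound 2 shares that position, so only compound 1 carries a measured apparent permeability. The next entry is compound 4 (`CC(=O)N1CCN(c2cc(-c3cc(Cl)c4c(N)ncnn34)ccc2C(C)O)C(=O)C1(C)C`), which has 1-hydroxyethyl in place of methylsulfonyl on an aromatic carbon. Within the data shown here, the series holds no measured step at this place, and with compound 3 unmeasured, no step from it can be stated. Among the measured compounds shown here, the only anchor is compound 1 at 150 nm/s in this assay, which differs from compound 4 at the same place. The expectation is a result close to that anchor, perhaps slightly lower, with a gap not beyond the usual scatter. Compound 4 is expected at 100 nm/s (estimated range 40 nm/s to 220 nm/s).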

Compound 4, apparent permeability: 31 nm/s
Beside the measured number, compound 4's estimate is 3.2-fold (0.51 log units) above it; measured number below the stated range.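

Among these compounds, the replacement of trifluoromethyl by 1-hydroxyethyl on an aromatic carbon gives a 4.8-fold lower number from compound 1 to compound 4 (0.68 log units; beyond the scatter) in this assay and is the only readable step at this position, which is ortho to a large group and para to a large group. It shows that, with the rest of the structure unchanged, the substituent at this position can move the apparent permeability beyond the usual scatter; steps involving compound 2 or compound 3 cannot be read, as neither has a number. No available evidence bears on the origin of this step.

A single step does not show whether the lower number tracks the hydrogen-bond donor counted for 1-hydroxyethyl or the departure of trifluoromethyl. As far as these compounds go, how a nitrile, a primary amine or a carboxylic acid at this position would compare remains open.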